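A few compounds are considered here, and "the series" means these few. Any claim that something is new, unique, unknown or untested is made for them only; others in the source may bear on it.

Measured so far in a functional assay on DU-145 cells (Homo sapiens) for cytotoxicity, read by MTT assay; a lower number here means a stronger inhibitor, a higher number a weaker inhibitor:
- compound 1 `COC(=O)C[C@@H]1C[C@@H](O)[C@H](C)[C@H](c2ccccc2)N1`: 6300 nM
- compound 2 `C[C@H]1[C@H](O)C[C@@H](CCO)N[C@H]1c1ccccc1`: 41600 nM

Not yet measured: compound 3 `C[C@H]1[C@H](O)C[C@@H](CC(=O)O)N[C@H]1c1ccccc1`.

Of the two numbers, the higher belongs to compound 2, at 41600 nM. Compound 1 is its nearest neighbour. Compound 3 carries carboxy in place of hydroxymethyl on a saturated chain carbon bound to a saturated ring carbon.

Among the compounds with values here, only one measured step bears on this change: a 6.6-fold higher number from compound 1 to compound 2 (0.82 log units; beyond the scatter). It is modest, and it replaces methoxycarbonyl with hydroxymethyl at the same place. From the compounds shown here alone, it does not show how carboxy behaves, so the direction remains open, though a shift toward compound 1 is possible. The expected change is small, an estimated 1.2-fold lower number from compound 2 to compound 3 (0.08 log units; within the scatter).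

For compound 3, the estimated value in this assay is 35000 nM, with an expected range of 12000 nM to 90000 nM.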

Compound 3, half-maximal inhibitory concentration: 46500 nM
Compound 3: the middle estimate sits 1.3-fold (0.12 log units) below what was measured; the range from low to high includes it.
By their numbers in this assay, from the lowest: compound 1; then compounds 2 and 3 (each within the scatter of the next).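

In this assay, the carboxy of compound 3 and the hydroxymethyl of compound 2 are not separated at this saturated chain carbon bound to a saturated ring carbon, with a 1.1-fold higher number from compound 2 to compound 3 (0.05 log units; within the scatter) and no order between them. Replacing the methyl of the methoxycarbonyl group with hydrogen gives a 7.4-fold higher number from compound 1 to compound 3 (0.87 log units; beyond the scatter) and so matches the earlier change to hydroxymethyl in direction. Among these three compounds, only compound 1 stands apart, so the lower number goes with the intact methyl ester and is not restored by either of the other two groups. From the compounds shown here alone, whether an ethyl ester, a primary amide or an amine at this place would stay with compound 1 or with compounds 2 and 3 remains open. No evidence at hand explains these differences.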